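Compound 4: Expected to Stay Inactive in Cell Toxicity

The source may report more compounds than this note shows. Statements on the series, on what has been measured and on what is new or still open speak of the compounds shown alone.

Compound 1 `COc1cccc(NC(=O)COc2cc(C)nc3ccc(OC)cc23)c1` in a toxicity assay on HepG2 cells (Homo sapiens) for inhibition, read by CellTiter-Glo, with a stated time of 48 h (a lower number here means a stronger inhibitor, a higher number a weaker inhibitor), gives > 100000 nM.
Compound 2 `COc1ccc2nc(C)cc(OCC(=O)Nc3ccc(Cl)c(OC)c3)c2c1` in this assay gives > 100000 nM.
Compound 3 `COc1ccc2nc(C)cc(OCC(=O)Nc3ccncn3)c2c1` in this assay gives > 100000 nM.

The value of compound 1 is a limit of the assay, not a number. The same holds for compound 2. The same holds for compound 3, so all three sit at the limit of > 100000 nM in this assay, at which 3 of the 3 values shown sit, and compound 3 stands only at that limit with no ordering among the three readable. The steps a step that the two limits leave unreadable from compound 1 to compound 2, a step that the two limits leave unreadable from compound 1 to compound 3 and a step that the two limits leave unreadable from compound 2 to compound 3 are unreadable for the same reason. Compound 4 `COc1ccc2nc(C)cc(OCC(=O)NNC(=O)c3ccncc3)c2c1` differs from compound 3 by ((pyridin-4-yl)carbonyl)amino in place of pyrimidin-4-yl on an amide-type nitrogen. Within the data shown here, no measured step tells how such a change moves this assay, and every measured value is a limit. Compound 4 is therefore expected to stay at the limit too, with an expected step of a number no higher from compound 3 to compound 4 (the limit leaves the size open) meaning no change beyond the scatter. The estimate for compound 4 is 100000 nM, within 30000 nM to 300000 nM.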

Compound 4, half-maximal inhibitory concentration: > 100000 nM
Compound 4: no number, only a limit; the forecaster's own chance of this, stated with the estimate: 85%; the middle value sits exactly at the limit.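

Compound 4 also gives only a limit of the assay, so its steps from compound 1, compound 2 and compound 3 cannot be read: the limit of > 100000 nM in this assay, at which 4 of the 4 values shown sit.
In this assay the compounds shown leave open which change, if any, would give a readable number.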